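A Saturated Ring in Place of a Fused Aromatic One

A few compounds are considered here, and "the series" means these few. Any claim that something is new, unique, unknown or untested is made for them only; others in the source may bear on it.

Compound 1 `COc1ccc2nccc(C3CN(CCCNCc4cc5ccccc5[nH]4)C(=O)O3)c2c1` gives 1580 nM in an in vitro functional assay on RBL cells for antagonist activity at C-C chemokine receptor type 8 (Homo sapiens), read by FLIPR and calcium flux; a higher number here means a weaker inhibitor, a lower number a stronger inhibitor.
Compound 2 `O=C1OC(c2cnc3ccccc3c2)CN1C1CCN(Cc2cc3ccccc3[nH]2)CC1` gives < 50200 nM in this assay, which is a limit of the assay rather than a number (the limit of < 50200 nM in this assay, at which 1 of the 3 values shown sits).
Compound 3 `COc1ccc2nccc(C3CN(C4CCN(Cc5cc6ccccc6o5)CC4)C(=O)O3)c2c1` gives 1260 nM in this assay.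

Of the two numbers measured, compound 3 carries the lower one, yet compound 3 and compound 1 sit within the scatter of each other, so no order between them can be drawn. Compound 4 `COc1ccc2nccc(C3CN(C4CCN(CC5CCCCC5)CC4)C(=O)O3)c2c1` differs from compound 3 in a single place: cyclohexyl in place of 1-benzofuran-2-yl on a saturated chain carbon bound to an amine nitrogen in a ring. Among the measured compounds shown here, no step between two measured compounds is available to show how such a swap has behaved here, so the size of this change rests on expectation alone. With a fused aromatic ring leaving and a plain saturated ring entering, the number in this assay is expected to rise, by an expected step of a 2.8-fold higher number from compound 3 to compound 4 (0.44 log units; beyond the scatter), somewhat beyond the scatter. Compound 4 is therefore estimated at 3500 nM, with a likely range from 1000 nM to 12000 nM.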

Compound 4, half-maximal inhibitory concentration: 7940 nM
Estimate against measurement, compound 4: 2.3-fold (0.36 log units) below; measured number inside the range.
By their numbers in this assay, from the lowest: compounds 3 and 1 (each within the scatter of the next); then compound 4.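

In this assay, among the compounds shown here, the change to cyclohexyl gives a 6.3-fold higher number from compound 3 to compound 4 (0.80 log units; beyond the scatter) and is the first step here that can be read in a single place. It shows that this position responds to what is attached, and that a plain saturated ring does not stand in for 1-benzofuran-2-yl without a loss, even though compound 4 still gives a real number and not a limit. Nothing in the data shown accounts for the size of this step.

From the compounds shown here alone, how a phenyl or a pyridyl group would read at this same place stays open, and so does whether the ring oxygen or the aromatic character of 1-benzofuran-2-yl accounts for the difference. A single pair also leaves open whether the step would hold on another core.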